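The source may report more compounds than this note shows. Statements on the series, on what has been measured and on what is new or still open speak of the compounds shown alone.

In a functional assay on HeLa cells (Homo sapiens) for cytotoxicity, read by MTT assay, with a stated time of 48 h (a higher number here means a weaker inhibitor, a lower number a stronger inhibitor), compound 1 (`C=C1CCC[C@]2(C)CCC(C=O)=CC[C@@]12C`) gives 191000 nM as its value, while compound 2 (`C=C1CCC[C@]2(C)CCC(c3cn(-c4ccc(OC)cc4)nn3)=CC[C@@]12C`) gives 43600 nM as its own. Compound 2 thus holds the lower of the two numbers, and its gap to compound 1 lies beyond the scatter. Compound 3 (`C=C1CCC[C@]2(C)CCC(c3cn(-c4ccc(C(C)=O)cc4)nn3)=CC[C@@]12C`) has not yet been measured. It differs from compound 2 in one place, where 4-methoxyphenyl becomes 4-acetylphenyl: acetyl in place of methoxy on an aromatic carbon, para to a large group (acetyl in place of methoxy on an aromatic carbon). Among the measured compounds shown here, no measured pair of compounds shows a change at this place, so the data give no direction for it. In this assay no step beyond the scatter is expected, and this expectation starts from compound 2 at 43600 nM as the closest measured structure. The expected result is a small step of a 1.1-fold lower number from compound 2 to compound 3 (0.04 log units; within the scatter) that stays within the scatter. Compound 3 is estimated at 40000 nM with an expected range from 15000 nM to 100000 nM in this measurement.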

Compound 3, half-maximal inhibitory concentration: 15100 nM
Beside the measured number, compound 3's estimate is 2.6-fold (0.42 log units) above it; low and high end bracket the measured number.
By their numbers in this assay, from the lowest: compound 3; then compound 2; then compound 1.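

In this assay, acetyl in place of methoxy on an aromatic carbon, para to a large group, gives a 2.9-fold lower number from compound 2 to compound 3 (0.46 log units; beyond the scatter). Among the compounds shown here, this is the first pair that differs in one place, so it gives the first direction for this position: what sits on the six-membered aromatic ring can move the number beyond the scatter, and here the move is downward. The change swaps methoxy, with 2 heavy atoms, for acetyl, with 3 heavy atoms and a double bond outside aromatic rings, while the count of 1 hydrogen-bond acceptor stays the same, but nothing measured here explains why the number falls.

This direction rests on a single step, so the compounds shown cannot tell whether it extends to other groups at this place, such as an amine, a carboxylic acid or a nitrile. They also leave open whether a longer chain ending in a carbonyl, such as propanoyl, would lower the number further than acetyl or raise it again.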